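Swapping the ring beside the nitrogen: from pyridine to furan

This account rests on a few compounds, and the source may have more. Where it says the series, first, only, none or still open, it means among the compounds named here.

Measured so far:
Compound 1, `Oc1cccc(-c2cc(-c3cccnc3)nc(-c3cccc(Cl)c3)c2)c1`, gives 27.6% in an assay on isolated protein for inhibition of DNA topoisomerase 1 (Homo sapiens), with a stated time of 30 min, tested at 100 uM; a higher number here means a stronger effect of the compound at the concentration tested, a lower number a weaker effect.
Compound 2, `Oc1cccc(-c2cc(-c3cccc(Cl)c3)nc(-c3ccccn3)c2)c1`, gives 0.4% in this assay.

Among the compounds with values here, of the two compounds measured, compound 2 stands lowest in this assay; the only measured step, a number 27.2 percentage points lower from compound 1 to compound 2 (beyond the scatter), moves the ring at the same position. Compound 3, `Oc1cccc(-c2cc(-c3cccc(Cl)c3)nc(-c3ccco3)c2)c1`, is not yet measured. It differs from compound 2 in one place: furan-2-yl in place of pyridin-2-yl on an aromatic carbon. Within the data shown here, no measured step pairs pyridin-2-yl with furan-2-yl, so the one step that bears on this position only shows that changing the ring there can shift the read-out by a modest amount, and that compound 2 sits near the bottom of the scale, where little room remains for a further fall. An upward step of unknown size, or none beyond the scatter, is therefore expected; the estimate for compound 3 is 10%, between 0% and 35%, which means an expected step of a number 9.6 percentage points higher from compound 2 to compound 3 (within the scatter).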

Compound 3, a percentage reported as inhibition, at one concentration (the size of the read-out at that concentration, not a potency): 5.5%
For compound 3 the middle estimate is 4.5 percentage points above the measured one; the measured number falls inside the stated range.
By their numbers in this assay, from the lowest: compounds 2 and 3 (each within the scatter of the next); then compound 1.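

Furan-2-yl in place of pyridin-2-yl swaps a six-membered ring holding a nitrogen for a five-membered ring holding an oxygen, yet in this assay this gives a number 5.1 percentage points higher from compound 2 to compound 3 (within the scatter), so the two rings cannot be told apart here. Against pyridin-3-yl, furan-2-yl gives a number 22.1 percentage points lower from compound 1 to compound 3 (beyond the scatter), so the low read-out is not tied to pyridin-2-yl alone, and among these three rings only pyridin-3-yl stands clear of the others. Nothing available explains this difference.

As far as these compounds go, it remains open what a plain phenyl ring or pyridin-4-yl would give at this position, and whether an amine or a carboxylic acid on the ring there would lift the read-out past that of compound 1. Each number also comes from a single concentration, so none of them gives a potency.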